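Chloro for methoxy on the aminoamino-bearing core

The source may hold more compounds than are shown below. What is called first, only, known or untested is meant among the compounds shown, and "the series" means these compounds.

Compound 2 `COc1ccc(-c2nc(NN)n(C)c(=O)c2C#N)cc1` gives 32 ug/mL in a functional assay, with a stated time of 10 min (on this read-out higher numbers stand for weaker inhibition and lower numbers for stronger inhibition), the lowest of the three numbers, though neither of the others lies beyond the scatter. Compound 3 `Cn1c(NN)nc(-c2ccccc2Cl)c(C#N)c1=O` gives 46 ug/mL and compound 1 `COc1ccc(-c2nc(SC)n(C)c(=O)c2C#N)cc1` gives 48 ug/mL. Within the data shown here, the only measured step, a 1.5-fold lower number from compound 1 to compound 2 (0.18 log units; within the scatter), exchanged a group on the shared core and stayed within the scatter. Compound 4 `Cn1c(NN)nc(-c2ccc(Cl)cc2)c(C#N)c1=O` differs from compound 2 by chloro in place of methoxy on an aromatic carbon. Among the measured compounds shown here, no measured step touches this aromatic carbon, so the step from compound 1 to compound 2 bears on it only as a sign that single exchanges have so far not moved the number beyond the scatter. In this assay compound 4 is therefore expected to show a 1.1-fold higher number from compound 2 to compound 4 (0.04 log units; within the scatter), no step beyond the scatter. The estimate for compound 4 is 35 ug/mL, with a range of 17 ug/mL to 70 ug/mL.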

Compound 4, half-maximal inhibitory concentration: 41 ug/mL
Estimate against measurement, compound 4: 1.2-fold (0.07 log units) below; the measured number falls inside the stated range.
By their numbers in this assay, from the lowest: compounds 2, 4, 3 and 1 (each within the scatter of the next).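

On the aromatic carbon para to a large group, chloro in place of methoxy gives a 1.3-fold higher number from compound 2 to compound 4 (0.11 log units; within the scatter) in this assay, the only step shown at this position. The exchange takes away the hydrogen-bond acceptor counted in methoxy, and the number stays within the scatter. Nothing available explains this outcome.

On these data alone, whether an amine or a carboxylic acid on this carbon would move the number beyond the scatter remains open. Also open, as far as these compounds go, is whether chloro gives the same result with methylsulfanyl in place of aminoamino on the shared core.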